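Chromone acrylamide series: amide nitrogen substituent notes

The compounds below may be only part of what the source reports. "The series", "measured", "known", "first", "only" and "open" are said of these compounds alone.

Compound 1 `COc1ccc2c(=O)c(/C=C/C(=O)NCc3ccc(F)cc3)coc2c1`: > 100000 nM
Compound 2 `COc1ccc2c(=O)c(/C=C/C(=O)Nc3ccccc3OC)coc2c1`: > 100000 nM

In a functional assay on A549 cells (Homo sapiens) for inhibition, read by MTT assay, with a stated time of 48 h (a higher number here means a weaker inhibitor, a lower number a stronger inhibitor), compound 1 gives only a limit, > 100000 nM. In this assay compound 2 likewise gives only a limit, > 100000 nM. Both values sit at the same point, (the limit of > 100000 nM in this assay, at which 2 of the 2 values shown sit), so the step that the two limits leave unreadable from compound 1 to compound 2 cannot be read. Compound 2 therefore stands at the limit of this assay, with no number of its own.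

Compound 3 `COc1ccc2c(=O)c(/C=C/C(=O)Nc3ccc(C)cc3)coc2c1` differs from compound 2 by 4-methylphenyl in place of 2-methoxyphenyl on an amide-type nitrogen. Going by the values given here, the only measured step is the unreadable one, so it supplies no size or direction that could be carried over to this change; no measured pair bears on it with a readable size. The expectation for compound 3 in this assay is therefore another limit rather than a number, an expected step of a number no higher from compound 2 to compound 3 (the limit leaves the size open) of no readable size. Compound 3 is estimated at 100000 nM, with a range from 30000 nM to 300000 nM.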

Compound 3, half-maximal inhibitory concentration: 17500 nM
Compound 3: the middle estimate sits 5.7-fold (0.76 log units) above what was measured; measured number outside the range, below it.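

In this assay, 4-methylphenyl on the amide-type nitrogen gives an at least 5.7-fold lower number from compound 2 to compound 3 (0.75 log units; beyond the scatter), which shows that a change at this position can bring the series within measurable range. Against the benzyl-type substituent, the same group gives an at least 5.7-fold lower number from compound 1 to compound 3 (0.75 log units; beyond the scatter), so compound 3 stands apart from both of the other compounds shown. Both steps give only a minimum size, as compound 1 and compound 2 remain at the assay limit with no number of their own: the limit of > 100000 nM in this assay, at which 2 of the 3 values shown sit.

The compounds shown do not separate the gain of the methyl group from the loss of the methoxy group, or the loss of the 4-fluorobenzyl group in the other comparison. An unsubstituted phenyl group, or a phenyl ring carrying an amine or a carboxylic acid, would leave open how far this step extends.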